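Acetyl to 4-Methoxyphenyl: Expected Cytotoxicity of Compound 4

This account rests on a few compounds, and the source may have more. Where it says the series, first, only, none or still open, it means among the compounds named here.

Of the compounds shown here, three built on a shared core have been measured in a functional assay on PC-12 cells (Rattus norvegicus) for cytotoxicity, read by MTT assay, with stated times of 3 h and 2 h, tested at 0.1 uM; on this read-out lower numbers stand for a weaker effect and higher numbers for a stronger effect at the one concentration tested. Compound 1 `Cc1cc(=O)oc2cc(OCCCn3cc(CNC(=O)CCCCC4CCSS4)nn3)ccc12` gives 44.8%, compound 2 `O=C(CCCCC1CCSS1)NCc1cn(CCCCOc2ccc3cc(-c4ccc(Cl)cc4)c(=O)oc3c2)nn1` gives 38.8%, and compound 3 `CC(=O)c1cc2ccc(OCCCCCn3cc(CNC(=O)CCCCC4CCSS4)nn3)cc2oc1=O` gives 28.9%. Compound 3 stands lowest of the three numbers; its nearest neighbour is compound 2, whose number lies within the usual scatter of it, while compound 1 lies beyond that scatter above it.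

Compound 4 `COc1ccc(-c2cc3ccc(OCCCCCn4cc(CNC(=O)CCCCC5CCSS5)nn4)cc3oc2=O)cc1` has not yet been measured. It differs from compound 3 in one place: 4-methoxyphenyl in place of acetyl on an aromatic carbon. Going by the values given here, no measured pair differing in a single place is available, so the size of this step cannot be read off directly. What the numbers do show is that compound 2, which also bears an aromatic ring where compound 3 bears its acetyl, sits within the scatter of compound 3 in this assay. On that basis the step is expected to be small, a number 5.1 percentage points higher from compound 3 to compound 4 (within the scatter), with no change beyond the scatter in either direction. Compound 4 is therefore estimated at 34% in this assay, with a range from 20% to 48%.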

Compound 4, a percentage reported as activity, at one concentration (the size of the read-out at that concentration, not a potency): 34.5%
For compound 4 the middle estimate is 0.5 percentage points below the measured one; the measured number falls inside the stated range.
By their numbers in this assay, from the lowest: compounds 3, 4, 2 and 1 (each within the scatter of the next, the first and the last beyond it).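

Going by these compounds alone, the step of a number 5.6 percentage points higher from compound 3 to compound 4 (within the scatter) gives the first direct reading at this position in this assay, on the aromatic carbon two atoms from the ring oxygen. It shows that acetyl, with 3 heavy atoms and no ring, can give way to 4-methoxyphenyl, with 8 heavy atoms and a six-membered aromatic ring, without a change beyond the scatter, while the hydrogen-bond donor and acceptor counts stay the same. Nothing available explains this result, so it stands as an observation about this one pair at the one concentration tested.

Steps involving compound 1 or compound 2 cannot be read, since each differs from the others in more than one place. From the compounds shown here alone, it remains open whether an amine or a carboxylic acid at this position would behave the same way, and whether a longer chain would alter the reading for compound 4.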